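The source may hold more compounds than are shown below. What is called first, only, known or untested is meant among the compounds shown, and "the series" means these compounds.

Series notes. The shared core is carried by compound 1 `CCOC(=O)C1=C(C)NC(C)=C(C(=O)OCC)C1c1csc(-c2ccc(Cl)cc2)n1`, compound 2 `CC1=C(C(=O)OC2CCCC2)C(c2csc(-c3ccc(Cl)cc3)n2)C(C(=O)OC2CCCC2)=C(C)N1` and compound 3 `COC(=O)C1=C(C)NC(C)=C(C(=O)OCc2ccccc2)C1c1csc(-c2ccc(Cl)cc2)n1`, which differ only in their ester groups. In an assay on isolated protein for antagonist activity at Voltage-dependent L-type calcium channel subunit alpha-1C (Cavia porcellus), with a stated time of 15 min (a lower number here means a stronger inhibitor, a higher number a weaker inhibitor), compound 1 gives 3650 nM, the lowest of the three numbers. Compound 2 gives 19000 nM, a step beyond the scatter from compound 1, and compound 3 gives 64900 nM, a higher number still. Among the measured compounds shown here, no pair among the three differs in a single place, so neither gap can be tied to one change; compound 3 also carries a methyl ester where compound 1 carries ethyl.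

Compound 4 `CCOC(=O)C1=C(C)NC(C)=C(C(=O)OC(C)c2ccccc2)C1c1csc(-c2ccc(Cl)cc2)n1` is not yet measured. It differs from compound 1 in one place: phenyl in place of hydrogen on a saturated chain carbon bound to an oxygen next to a carbonyl group and a saturated chain carbon. A phenyl-bearing ester in compound 3 went with the highest number seen, though that compound also changed the other ester, so the comparison is not clean. Among the three measured compounds, the larger esters of compound 2 and compound 3 carry the higher numbers, and none of the three goes against this. On that basis compound 4 is expected to give a number higher than compound 1 by a step beyond the scatter, a 3.3-fold higher number from compound 1 to compound 4 (0.52 log units; beyond the scatter). The estimate for compound 4 in this assay is 12000 nM, with a range from 4000 nM to 40000 nM.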

Compound 4, half-maximal inhibitory concentration: 13800 nM
For compound 4 the middle estimate is 1.2-fold (0.06 log units) below the measured one; measured number inside the range.
By their numbers in this assay, from the lowest: compound 1; then compounds 4 and 2 (each within the scatter of the next); then compound 3.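

In this assay, among the compounds shown here, ethyl to 1-phenylethyl on one ester gives a 3.8-fold higher number from compound 1 to compound 4 (0.58 log units; beyond the scatter), the first step that can be tied to a single change, since the gaps among the earlier compounds each involved more than one place. With the other ester held as ethyl, the step shows that this position alone responds to phenyl in place of hydrogen on a saturated chain carbon bound to an oxygen next to a carbonyl group and a saturated chain carbon, and the response is a weaker inhibitor by an amount beyond the scatter. No measurement to hand explains this rise, so the step stands as a description of this one change.

A single replacement cannot show whether the rise follows from phenyl in particular or would also appear with another group at the same carbon, such as a cyclohexyl ring, a longer chain or a dimethylamino group. Going by these compounds, how the same phenyl replacement reads on the other ester, and whether an ester carrying a terminal amine or a carboxylic acid in place of ethyl would move the number in either direction, also remains open.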